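The source may hold more compounds than are shown below. What is called first, only, known or untested is meant among the compounds shown, and "the series" means these compounds.

Measured in an ADME assay on BCBL1 cells (Homo sapiens) for cytotoxicity, with a stated time of 7 days; a higher number here means that more compound is tolerated, a lower number that less compound is tolerated:
Compound 1 `Nc1nc(OCC(F)(F)F)c2ncn(/C=C3/CC3(CO)CO)c2n1`: > 20000 nM
Compound 2 `C=CCOc1nc(N)nc2c1ncn2/C=C1/CC1(CO)CO`: > 20000 nM
Compound 3 `CCCCCCSc1nc(N)nc2c1ncn2/C=C1/CC1(CO)CO`: > 20000 nM

Each of these three values is a limit of the assay and not a number. Compound 3 therefore has no readable rank, and it stands with the others at the limit of > 20000 nM in this assay, at which 3 of the 3 values shown sit. Compound 4 `CCCCCCOc1nc(N)nc2c1ncn2/C=C1/CC1(CO)CO` has hexyloxy in place of hexylsulfanyl on an aromatic carbon. The nearest measured change is a step that the two limits leave unreadable from compound 2 to compound 3, which also swaps the group on an aromatic carbon. The others, a step that the two limits leave unreadable from compound 1 to compound 3 and a step that the two limits leave unreadable from compound 1 to compound 2, are equally unreadable, so none of them gives a size. Among the compounds with values here, with no measured step to suggest otherwise, the expectation is a step that the limit leaves unreadable from compound 3 to compound 4, with nothing beyond the scatter in either direction. For compound 4 the estimated value is 22000 nM, within an expected range of 9000 nM to 50000 nM.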

Compound 4, half-maximal cytotoxic concentration: > 20000 nM
Compound 4 gave a limit, no number (the forecaster's own chance of this, stated with the estimate: 80%); the middle value lies beyond the limit too.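

Compound 4 also gives only a limit, not a number, so its steps from compound 1, compound 2 and compound 3 cannot be read: the limit of > 20000 nM in this assay, at which 4 of the 4 values shown sit.

The compounds shown leave open whether 2,2,2-trifluoroethoxy, allyloxy, hexylsulfanyl and hexyloxy differ at all in this assay.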